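The compounds below may be only part of what the source reports. "The series", "measured", "known", "first", "only" and "open" are said of these compounds alone.

Compound 1 `Cc1cc(NCc2ccccn2)n2nc(C)c(-c3ccc(F)cc3)c2n1` gives < 5000 nM in a physicochemical assay for solubility, read by HPLC, using the shake flask method, measured as kinetic solubility, with a stated time of 2 h, at pH 7.4 (a higher number here means a more soluble compound, a lower number a less soluble compound), which is a limit of the assay and not a number.
Compound 2 `COc1ccc(-c2c(C)nn3c(NCc4ccccn4)cc(C)nc23)cc1` gives < 5000 nM in this assay, again a limit.
Compound 3 `COc1ccc(-c2cnn3c(NCc4ccccn4)cc(C)nc23)cc1` gives < 5000 nM in this assay, also a limit.

Compound 2 thus stands only at a limit, and its two neighbours stand at the same limit: the limit of < 5000 nM in this assay, at which 3 of the 3 values shown sit. The step that the two limits leave unreadable from compound 1 to compound 2 and the step that the two limits leave unreadable from compound 2 to compound 3 cannot be read for size. Compound 4 `Cc1cc(NCc2ccccn2)n2nc(C)c(Nc3ccccc3)c2n1` differs from compound 2 by anilino in place of 4-methoxyphenyl on an aromatic carbon. Going by the values given here, no measured step bears on this change in a readable way, so no direction beyond the scatter can be expected. Compound 4 is estimated at 3000 nM, with a range from 500 nM to 15000 nM, an expected step that the limit leaves unreadable from compound 2 to compound 4.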

Compound 4, solubility: 7800 nM
Estimate against measurement, compound 4: 2.6-fold (0.41 log units) below; the measured number falls inside the stated range.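

Compound 4 is the only compound shown that stands clear of the limit: the limit of < 5000 nM in this assay, at which 3 of the 4 values shown sit.

Going by these compounds alone, with anilino on this aromatic carbon, this assay gives the only readable steps, an at least 1.5-fold higher number from compound 2 to compound 4 (0.19 log units; that floor lies within the scatter) and an at least 1.5-fold higher number from compound 1 to compound 4 (0.19 log units; that floor lies within the scatter). Both are floors within the scatter, so neither shows a change beyond it, and the other steps still cannot be read.

The compounds shown leave open how far compound 1 and compound 2 really lie from compound 4. They also leave open whether a benzylamino or morpholine group on this carbon would read like anilino.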